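Aryl Swap in a Series Without Measurable Cytotoxicity

A few compounds are considered here, and "the series" means these few. Any claim that something is new, unique, unknown or untested is made for them only; others in the source may bear on it.

Compounds measured so far:
Compound 1 `Cc1nc(-c2cccnc2)sc1-c1nnc(Cc2ccccc2)o1` gives in an ADME assay on HeLa cells (Homo sapiens) for cytotoxicity, read by MTT assay (on this read-out higher numbers stand for lower toxicity in this test and lower numbers for higher toxicity in this test), a value of > 100 ug/mL, a limit of the assay rather than a number.
Compound 2 `Cc1nc(-c2cccnc2)sc1-c1nnc(-c2ccc(Cl)cc2)o1` gives > 100 ug/mL, again a limit.
Compound 3 `Cc1nc(-c2cccnc2)sc1-c1nnc(-c2cccc(Cl)c2Cl)o1` gives > 100 ug/mL, also a limit.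

Compound 3 therefore sits at the limit of > 100 ug/mL in this assay, at which 3 of the 3 values shown sit. The next compound, compound 4 `Cc1cccc(-c2nnc(-c3sc(-c4cccnc4)nc3C)o2)c1`, differs from compound 3 by 3-methylphenyl in place of 2,3-dichlorophenyl on an aromatic carbon. The measured steps that bear on this change are a step that the two limits leave unreadable from compound 1 to compound 2, a step that the two limits leave unreadable from compound 1 to compound 3 and a step that the two limits leave unreadable from compound 2 to compound 3. None of them could be sized; every value is a limit. No step beyond the scatter is expected here, and the estimated step that the limit leaves unreadable from compound 3 to compound 4 most likely stays unreadable as well. Compound 4 is therefore expected to give 150 ug/mL, within 60 ug/mL to 400 ug/mL.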

Compound 4, half-maximal cytotoxic concentration: > 100 ug/mL
Compound 4 was reported as a limit; the forecaster's own chance of this, stated with the estimate: 80%; the middle value does not contradict the limit.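

Compound 4 is again a limit, like compound 1, compound 2 and compound 3, so no step among these four can be read in this assay: the limit of > 100 ug/mL in this assay, at which 4 of the 4 values shown sit.
The compounds shown leave open at what concentration any of them becomes toxic, and whether swapping these groups changes that.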